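The source may hold more compounds than are shown below. What is called first, only, known or untested is meant among the compounds shown, and "the series" means these compounds.

In a functional assay on BXPC-3 cells (Homo sapiens) for antiproliferative activity, read by MTT assay, with a stated time of 24 h; a lower number here means a stronger inhibitor, a higher number a weaker inhibitor:

Compound 1 `CCn1c(C(=O)N[C@@H](CO)C(C)C)ccc1C(CC)(CC)c1ccc(OCS(=O)(=O)c2ccccc2)c(C)c1`: 13200 nM
Compound 2 `CCn1c(C(=O)N[C@H](CO)CCO)ccc1C(CC)(CC)c1ccc(OCS(=O)(=O)c2ccccc2)c(C)c1`: 15900 nM
Compound 3 `CCn1c(C(=O)N[C@@H](CO)CCCO)ccc1C(CC)(CC)c1ccc(OCS(=O)(=O)c2ccccc2)c(C)c1`: 16400 nM

Compound 3 stands at 16400 nM, within the scatter of both other compounds. Compound 4 `CCn1c(C(=O)N[C@@H](CC(=O)O)C(=O)O)ccc1C(CC)(CC)c1ccc(OCS(=O)(=O)c2ccccc2)c(C)c1` keeps the shared core but carries 1,2-dicarboxyethyl on the amide-type nitrogen: a group of 8 heavy atoms (4 carbon, 4 oxygen; no ring) in place of a group of 7 heavy atoms (5 carbon, 2 oxygen; no ring), on an amide-type nitrogen. The measured changes at this nitrogen were all small: a 1.2-fold higher number from compound 1 to compound 2 (0.08 log units; within the scatter), a 1.2-fold higher number from compound 1 to compound 3 (0.09 log units; within the scatter) and a 1.0-fold higher number from compound 2 to compound 3 (0.01 log units; within the scatter). None of the three measured compounds carries 1,2-dicarboxyethyl, so these steps are only a loose guide and the range must stay wide. No change beyond the scatter is therefore expected in this assay. The expected step is a 1.2-fold higher number from compound 3 to compound 4 (0.09 log units; within the scatter). The estimate for compound 4 is 20000 nM, with an expected range from 8000 nM to 50000 nM.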

Compound 4, half-maximal inhibitory concentration: > 50000 nM
Compound 4: only a limit was reported (the forecaster's own chance of this, stated with the estimate: 15%); at least 2.5-fold (0.39 log units) between middle value and limit.
By their numbers in this assay, from the lowest: compounds 1, 2 and 3 (each within the scatter of the next). At a limit, above all of these: compound 4.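

In this assay compound 4 gives > 50000 nM as a limit of the assay and not as a number. Earlier changes on the amide-type nitrogen stayed within the scatter, so this position had seemed to accept any of the groups shown. With 1,2-dicarboxyethyl, the steps (an at least 3.0-fold higher number from compound 3 to compound 4 (0.48 log units; beyond the scatter)), (an at least 3.1-fold higher number from compound 2 to compound 4 (0.49 log units; beyond the scatter)) and (an at least 3.7-fold higher number from compound 1 to compound 4 (0.57 log units; beyond the scatter)) all lie beyond the scatter, so the group on this nitrogen can matter.

Going by these compounds, how large the true step is remains unknown. On these data alone, it also remains open whether a chain with a single carboxylic acid, or an amine, would behave like 1,2-dicarboxyethyl.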